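A few compounds are considered here, and "the series" means these few. Any claim that something is new, unique, unknown or untested is made for them only; others in the source may bear on it.

Three compounds in this series share one core and differ only in the aryl group on the sulfonyl sulfur. Compound 1 `O=S(=O)(Nc1ccc(-c2nc3ccccc3o2)cc1)c1cccc(F)c1` and compound 2 `O=S(=O)(Nc1ccc(-c2nc3ccccc3o2)cc1)c1cccc(C(F)(F)F)c1` were both measured in an assay on cells for inhibition of HSP60/HSP10 (Homo sapiens), with a stated time of 60 min; a higher number here means a weaker inhibitor, a lower number a stronger inhibitor. Compound 1 gives 71000 nM, and compound 2 gives 57000 nM. Between them the change is trifluoromethyl in place of fluoro on an aromatic carbon, and the step is a 1.2-fold lower number from compound 1 to compound 2 (0.10 log units; within the scatter). Compound 3 `O=S(=O)(Nc1ccc(-c2nc3ccccc3o2)cc1)c1ccc(F)cc1` is built from the same atoms as compound 1, joined differently; the cores of compound 1 and compound 3 differ by 4-fluorophenyl in place of 3-fluorophenyl on a sulfonyl sulfur, and the step is a 1.0-fold higher number from compound 1 to compound 3 (0.01 log units; within the scatter). In this assay compound 3 gives 73000 nM. Compound 4 `O=S(=O)(Nc1ccc(-c2nc3ccccc3o2)cc1)c1ccc(C(F)(F)F)cc1` has not yet been measured. It differs from compound 3 by trifluoromethyl in place of fluoro on an aromatic carbon, the same kind of change as that from compound 1 to compound 2, though here the place is para to a large group rather than meta to a large group. Because of a 1.2-fold lower number from compound 1 to compound 2 (0.10 log units; within the scatter) a similarly small step is expected, a 1.2-fold lower number from compound 3 to compound 4 (0.09 log units; within the scatter), since nothing in the three measured values points to a larger effect. Compound 4 is therefore estimated to give 60000 nM in this assay, with a likely range from 30000 nM to 120000 nM.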

Compound 4, half-maximal inhibitory concentration: 50000 nM
Compound 4: middle estimate off by 1.2-fold (0.08 log units), on the high side; measured number inside the range.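

In this assay, trifluoromethyl in place of fluoro para to a large group gives a 1.5-fold lower number from compound 3 to compound 4 (0.16 log units; within the scatter), and this step cannot be told apart from the one seen earlier for the same change: the same change on two cores in this assay, a 1.2-fold lower number (0.10 log units; within the scatter) from compound 1 to compound 2 and a 1.5-fold lower number (0.16 log units; within the scatter) from compound 3 to compound 4, 1.2-fold (0.07 log units) apart, within the scatter of two such steps

Among the compounds shown here, both steps lie within the scatter, so the agreement shows only that on these two cores the change has no effect that this assay can separate from repeat measurement. For the compounds shown here, it does not show that the change brings a real gain in strength on either core, and with no step large enough to read, these pairs offer little test of whether a sizeable effect would carry from one core to another.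

The compounds shown hold only fluoro and trifluoromethyl on the aryl group, and it stays open whether a carboxylic acid, an amine or a methoxy group there would move the number beyond the scatter. Also open, on these data alone, is whether a change to the shared core itself, rather than to the aryl group on the sulfonyl sulfur, would do so.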